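A few compounds are considered here, and "the series" means these few. Any claim that something is new, unique, unknown or untested is made for them only; others in the source may bear on it.

Measured in a functional assay with Oryctolagus cuniculus as the target; a lower number here means a stronger inhibitor, a higher number a weaker inhibitor:
- compound 1 `COc1ccc(-c2nc(CN)sc2-c2ccc(OC)cc2)cc1`: > 100 nM (a limit of the assay)
- compound 2 `COc1ccc(-c2nc(CNC(=O)c3cccnc3)sc2-c2ccc(OC)cc2)cc1`: 25 nM
- compound 3 `CCN(CC)C(=O)c1nc(-c2ccc(OC)cc2)c(-c2ccc(OC)cc2)s1`: < 10 nM (a limit of the assay)

Compound 3 stands at the limit of < 10 nM in this assay, at which 1 of the 3 values shown sits, so it has a limit and no exact number. Compound 4 `COc1ccc(-c2nc(C(=O)N3CCCCC3CCO)sc2-c2ccc(OC)cc2)cc1` keeps the shared core and has 2-(2-hydroxyethyl)piperidin-1-yl in place of diethylamino on a carbonyl carbon.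

Within the data shown here, no measured step exchanges diethylamino for another group on that carbonyl carbon, so the evidence is indirect. The closest comparison is an at least 2.5-fold lower number from compound 2 to compound 3 (0.39 log units; beyond the scatter). The wider changes are an at least 10-fold lower number from compound 1 to compound 3 (1.00 log units; beyond the scatter) and an at least 4.0-fold lower number from compound 1 to compound 2 (0.60 log units; beyond the scatter). All three sizes are bounds, not exact sizes, and they concern other changes, so they set no firm size for the new step.

The expectation is anchored on compound 3, whose < 10 nM is a limit. Compound 2, at 25 nM, marks a nearby measured number in this assay. The expected change is small, towards a weaker inhibitor, and is estimated as an at least 1.5-fold higher number from compound 3 to compound 4 (0.17 log units; that floor lies within the scatter). For compound 4 the expected value is 15 nM, with an estimated range of 3 nM to 80 nM.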

Compound 4, half-maximal inhibitory concentration: 45 nM
Compound 4: middle estimate off by 3.0-fold (0.48 log units), on the low side, within the range that was stated.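

Earlier steps replaced the whole group on the aromatic carbon, whereas this one keeps the carbonyl and changes only the amine part. In this assay, 2-(2-hydroxyethyl)piperidin-1-yl in place of diethylamino on the carbonyl carbon gives an at least 4.5-fold higher number from compound 3 to compound 4 (0.65 log units; beyond the scatter), so the group on that carbonyl affects the read-out and the carbonyl alone does not fix it. This size is a bound and not an exact figure, because compound 3 carries only a limit of the assay: the limit of < 10 nM in this assay, at which 1 of the 4 values shown sits.

The change brings in a six-membered non-aromatic ring and a hydroxyethyl chain together, so the compounds shown do not say which of the two accounts for the weaker inhibition, and unsubstituted piperidin-1-yl would separate them. From the compounds shown here alone, whether a methoxyethyl chain in place of the hydroxyethyl chain, or the same hydroxyethyl chain on a plain open-chain amine at this carbonyl, would stay closer to compound 3 also remains open.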